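Replacing the 2,3-dichlorophenyl group of compound 2

A few compounds are considered here, and "the series" means these few. Any claim that something is new, unique, unknown or untested is made for them only; others in the source may bear on it.

Going by the values given here, in a functional assay on HL-60 cells (Homo sapiens) for inhibition, read by MTT assay, with a stated time of 72 h (on this read-out lower numbers stand for stronger inhibition and higher numbers for weaker inhibition), compound 2 (`Cc1nc(-c2ccccc2)c(C(=O)N2CCN(c3cccc(Cl)c3Cl)CC2)o1`) gives 133 nM as the only number so far. Compound 1 (`CCc1nc(-c2ccc(C(C)(C)C)cc2)c(C(=O)N2CCN(c3cccc(OC)c3)CC2)o1`) gives "not active" (no number reported) in the same test, and compound 3 (`O=C(c1oc(C(F)(F)F)nc1-c1cccc(F)c1)N1CCN(c2cccc(Cl)c2)CC1`) gives "not active" (no number reported) there too. Among the compounds with values here, both differ from compound 2 in more than one place, so no single-change step has been measured.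

Compound 4 (`Cc1ccc(C)c(N2CCN(C(=O)c3oc(C)nc3-c3ccccc3)CC2)c1`) carries 2,5-dimethylphenyl in place of 2,3-dichlorophenyl on an amine nitrogen in a ring. The change from compound 2 is 2,5-dimethylphenyl in place of 2,3-dichlorophenyl on an amine nitrogen in a ring and the rest stays the same.

With only compound 2 at 133 nM as an anchor, a moderate loss is expected in this assay and the estimated step is a 2.6-fold higher number from compound 2 to compound 4 (0.42 log units; beyond the scatter) towards weaker inhibition. Compound 4 is estimated at 350 nM with a range from 70 nM to 2500 nM in this test.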

Compound 4, half-maximal inhibitory concentration: 31.3 nM
Estimate against measurement, compound 4: 11-fold (1.05 log units) above, outside the stated range (below it).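

In this assay the change on the amine nitrogen in a ring gives a 4.2-fold lower number from compound 2 to compound 4 (0.63 log units; beyond the scatter) and shows that chlorine is not required on this aryl group for inhibition. The leaving and entering groups both hold 8 heavy atoms and no hydrogen-bond donors or acceptors, so the step separates groups that match in those counts. Nothing measured here accounts for the gain.

From the compounds shown here alone, only these two aryl groups share this core, so the separate contributions of the methyl groups and their pattern stay open. Also open, going by these compounds, are how a carboxylic acid or an amine on this aryl group would read and whether the gain carries over to the cores of compound 1 and compound 3.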